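The source may report more compounds than this note shows. Statements on the series, on what has been measured and on what is new or still open speak of the compounds shown alone.

Measured compounds:
compound 1 `O=c1ccc2cc(OCc3cc(-c4ccccc4)no3)ccc2o1` gives 43300 nM in a functional assay on HL-60 cells (Homo sapiens) for cytotoxicity, read by MTT assay, with a stated time of 48 h; on this read-out lower numbers stand for stronger inhibition and higher numbers for weaker inhibition
compound 2 `O=c1ccc2cc(OCc3cn(-c4cccc(CO)c4)nn3)ccc2o1` gives "not determined" (no result reported) in this assay

Compound 2 stands nowhere on the numbers: no value was reported for it, so compound 1 alone anchors the series, and at a weak level. Compound 3 `O=c1ccc2cc(OCc3cn(-c4ccc([N+](=O)[O-])cc4)nn3)ccc2o1` carries 4-nitrophenyl in place of 3-(hydroxymethyl)phenyl on an aromatic nitrogen. Within the data shown here, with no measured step from compound 2 to build on, the change is expected to shift cytotoxicity only modestly in this assay, in either direction, probably not beyond the scatter, and compound 3 is taken to sit near the weak level of compound 1. Compound 3 is therefore estimated at 35000 nM, within 9000 nM to 130000 nM.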

Compound 3, half-maximal inhibitory concentration: 46000 nM
Compound 3: middle estimate off by 1.3-fold (0.12 log units), on the low side; the range from low to high includes it.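

In this assay compound 2 gives "not determined" (no result reported) and compound 3 gives 46000 nM, so no step can be read between them. No further data bear on this result.

The compounds shown leave open how 4-nitrophenyl compares with 3-(hydroxymethyl)phenyl on the shared core.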